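A few compounds are considered here, and "the series" means these few. Any claim that something is new, unique, unknown or untested is made for them only; others in the source may bear on it.

Of the compounds shown here, three built on one shared core have been tested in a functional assay on HeLa cells (Homo sapiens) for inhibition, read by MTT assay, with a stated time of 24 h; on this read-out higher numbers stand for weaker inhibition and lower numbers for stronger inhibition. Within the data shown here, compound 1 `CCOC(=O)C1=Cc2ccccc2OC1(OCc1cn(CC(=O)Nc2ccc(C)cc2)nn1)C(F)(F)F` gives 67400 nM, the only finished number among them. Compound 2 `O=C(O)C1=Cc2ccccc2OC1(OCc1cc(-c2ccc([N+](=O)[O-])cc2)no1)C(F)(F)F` reaches only a limit of the assay, > 150000 nM. Compound 3 `COc1ccc(-c2cc(COC3(C(F)(F)F)Oc4ccccc4C=C3C(=O)O)on2)cc1` likewise reaches only a limit, > 150000 nM. Among the measured compounds shown here, the single step between measured compounds that differ in one place, methoxy in place of nitro on an aromatic carbon, is a step that the two limits leave unreadable from compound 2 to compound 3, because both of its ends lie at the limit of > 150000 nM in this assay, at which 2 of the 3 values shown sit. For the measured compounds named here, compound 1 therefore stands alone as the one compound with a readable number, and the neighbours say nothing about how far that number moves when a group is swapped.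

Compound 4 `CCOC(=O)C1=Cc2ccccc2OC1(OCc1cn(CC(=O)NC2CCCCC2)nn1)C(F)(F)F` differs from compound 1 in one place: cyclohexyl in place of 4-methylphenyl on an amide-type nitrogen. Going by the values given here, no measured step touches the amide-type nitrogen or exchanges an aromatic ring for a non-aromatic one, so there is no earlier step to lean on. The step of a 1.2-fold higher number from compound 1 to compound 4 (0.07 log units; within the scatter) is therefore expected to stay within the usual scatter, with no direction favoured. Given how weakly compound 1 inhibits, a result that again ends at a limit is also a real possibility. Compound 4 is estimated at 80000 nM, within a range from 30000 nM to 160000 nM.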

Compound 4, half-maximal inhibitory concentration: 11400 nM
Estimate against measurement, compound 4: 7.0-fold (0.85 log units) above; the measured number lies below the stated range.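

Putting cyclohexyl in place of 4-methylphenyl on an amide-type nitrogen gives a 5.9-fold lower number from compound 1 to compound 4 (0.77 log units; beyond the scatter) in this assay. Among these compounds, this is the first step in the set that can be read as a size, and it shows that this position can move the number by more than the usual scatter, with the non-aromatic ring giving the stronger inhibition of the pair. Both groups carry a six-membered ring of carbon only, no net charge, and no hydrogen-bond donors or acceptors, and nothing measured here explains the step, which rests on this single pair of compounds.

From the compounds shown here alone, it remains open whether the aromatic ring itself matters or only the methyl on it, and a plain phenyl, a cyclopentyl or an open hexyl chain on the same nitrogen would help to separate these possibilities. Also open, going by these compounds, is whether the same swap would act in the same direction on a compound carrying a carboxylic acid in place of the ethyl ester on the shared core.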